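Swapping the benzyl group on the amine nitrogen of compound 3

The compounds below may be only part of what the source reports. "The series", "measured", "known", "first", "only" and "open" are said of these compounds alone.

Of the compounds shown here, three of a shared core have been measured in a physicochemical assay for acid dissociation. Compound 1 `COc1cccc(CNCCCNc2ccnc3cc(-c4ccc(C(C)(C)C)cc4)ccc23)c1O` gives 9.47, and compound 2 `COc1cccc(CNCCCNc2ccnc3cc(Cc4cc(C)cc(C)c4)ccc23)c1O` gives 9.47; the step of no change at the digits printed from compound 1 to compound 2 (within the scatter) lies far from the amine. Compound 3 `COc1ccc(F)cc1CNCCCNc1ccnc2cc(Oc3cccc(N(C)C)c3)ccc12` gives 9.28, the lowest of the three numbers, yet within the scatter of both compound 1 and compound 2.

Compound 4 `COc1cccc(CNCCCNc2ccnc3cc(Oc4cccc(N(C)C)c4)ccc23)c1O` has not been measured. It differs from compound 3 by 2-hydroxy-3-methoxyphenyl in place of 5-fluoro-2-methoxyphenyl on a saturated chain carbon bound to an amine nitrogen. Among the compounds with values here, no measured step covers this change directly; the only step, from compound 1 to compound 2, concerns the other end of the molecule and shows no change. Compound 1 and compound 2 both carry the group that enters in compound 4, and their values sit within the scatter of compound 3. The expectation for the step of a number 0.17 log units higher from compound 3 to compound 4 (within the scatter) in this assay is therefore no change beyond the scatter. Compound 4 is estimated at 9.45, with a range from 9.15 to 9.75.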

Compound 4, acid dissociation constant: 9.28
For compound 4 the middle estimate is 0.17 log units above the measured one, within the range that was stated.
By their numbers in this assay, from the lowest: compounds 3, 4, 1 and 2 (each within the scatter of the next).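

In this assay, the step at this position, 2-hydroxy-3-methoxyphenyl in place of 5-fluoro-2-methoxyphenyl on a saturated chain carbon bound to an amine nitrogen, now has a reading of its own (no change at the digits printed from compound 3 to compound 4 (within the scatter)). With that group held, 3-(dimethylamino)phenoxy on an aromatic carbon can also be read against the other two groups there (a number 0.19 log units lower from compound 2 to compound 4 (within the scatter); a number 0.19 log units lower from compound 1 to compound 4 (within the scatter)), so every step among these compounds lies within the scatter. Nothing measured here offers an explanation for this result.

The compounds shown do not separate the contributions of the hydroxy, methoxy and fluoro groups, which differ together in this swap. Going by these compounds, whether a carboxylic acid or a second amine in place of 2-hydroxy-3-methoxyphenyl would give a step beyond the scatter remains open.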